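A few compounds are considered here, and "the series" means these few. Any claim that something is new, unique, unknown or untested is made for them only; others in the source may bear on it.

Of the compounds shown here, two built on a shared core have been measured in a functional assay on MCF7 cells (Homo sapiens) for cytotoxicity; a higher number here means that more compound is needed for the effect, a lower number that less compound is needed. Compound 1 `CCC(CO)CCn1c(Cc2cc(OC)c(OC)c(OC)c2)nc2c(N)ncnc21` gives 19200000 nM, while compound 2 `COc1cc(Cc2nc3c(N)nc(F)nc3n2CCOC(C)C)cc(OC)c1OC` gives 769000000 nM. Of these two numbers, that of compound 2 is the higher, so more of compound 2 is needed for the effect than of compound 1; the two structures differ in more than one place, so this gap is read only from the two values themselves.

Compound 3 `COc1cc(Cc2nc3c(N)nc(F)nc3n2CC2CCCO2)cc(OC)c1OC` keeps the core of compound 2 and alters a single group: oxolan-2-yl in place of isopropoxymethyl on a saturated chain carbon bound to an aromatic nitrogen. The group that leaves and the group that enters are counted alike in heavy atoms and hydrogen-bond acceptors; the open chain is replaced by a ring. Among the measured compounds shown here, no measured pair shows such a change. The expected step in this assay is a 1.3-fold lower number from compound 2 to compound 3 (0.11 log units; within the scatter), small, in no set direction, and within the usual scatter. Compound 3 is therefore estimated at 600000000 nM, with a range from 150000000 nM to 2500000000 nM.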

Compound 3, half-maximal effective concentration: 147000000 nM
Compound 3: the middle estimate sits 4.1-fold (0.61 log units) above what was measured; the whole stated range lies above it.
By their numbers in this assay, from the lowest: compound 1; then compound 3; then compound 2.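

In this assay, putting oxolan-2-yl in place of isopropoxymethyl gives a 5.2-fold lower number from compound 2 to compound 3 (0.72 log units; beyond the scatter). Among the compounds shown here, this is the first measured step at this place, on a saturated chain carbon bound to an aromatic nitrogen, and it shows that the two groups are not interchangeable here, even though they are counted alike in heavy atoms and hydrogen-bond acceptors. Nothing in the data shown gives a reason for the step.

A single pair cannot tell whether it is the ring itself or the way the oxygen is held within it that goes with the lower number, and a cyclopentyl group or a dimethylamino group at this place would help separate the two. On these data alone, whether the same change would have a similar effect on the core of compound 1, which lacks the fluorine of compound 2 and compound 3, also remains open.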